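Cyclopropyl replaces 4-fluorophenyl on the shared core

The source may report more compounds than this note shows. Statements on the series, on what has been measured and on what is new or still open speak of the compounds shown alone.

Of the compounds shown here, three built on one core have been measured so far. In a functional assay on MOLT-4 cells (Homo sapiens) for antiproliferative activity, read by MTT assay, with a stated time of 48 h (a lower number here means a stronger inhibitor, a higher number a weaker inhibitor), compound 1 `O=C(CCCCCCn1cc(Nc2ncc(Cl)c(Nc3cccc(Cl)c3)n2)cn1)NO` gives 130 nM, compound 2 `CNc1nc(Nc2cnn(CCCCCCC(=O)NO)c2)ncc1Cl` gives 110 nM, and compound 3 `O=C(CCCCCCn1cc(Nc2ncc(Cl)c(Nc3ccc(F)cc3)n2)cn1)NO` gives 220 nM. Compound 3 therefore stands within the scatter of both other compounds, and the three cannot be ranked on these numbers.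

Compound 4 `O=C(CCCCCCn1cc(Nc2ncc(Cl)c(NC3CC3)n2)cn1)NO` carries cyclopropyl in place of 4-fluorophenyl on a nitrogen on an aromatic ring. Among the compounds with values here, three measured steps bear on this change: a 1.2-fold lower number from compound 1 to compound 2 (0.07 log units; within the scatter), a 1.7-fold higher number from compound 1 to compound 3 (0.23 log units; within the scatter) and a 2.0-fold higher number from compound 2 to compound 3 (0.30 log units; within the scatter). All three exchange groups at that same place, and none goes beyond the scatter. The last is the closest guide, since compound 2, like compound 4, has no aromatic ring in the group on that nitrogen.

No shift beyond the scatter is therefore expected in this assay, and the estimated step is a 1.7-fold lower number from compound 3 to compound 4 (0.23 log units; within the scatter). The estimate for compound 4 is 130 nM, with an expected range of 55 nM to 320 nM.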

Compound 4, half-maximal inhibitory concentration: 150 nM
The estimate for compound 4 lay 1.2-fold (0.06 log units) below the measured number; measured number inside the range.
By their numbers in this assay, from the lowest: compounds 2, 1, 4 and 3 (each within the scatter of the next).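

In this assay the steps of a 1.5-fold lower number from compound 3 to compound 4 (0.17 log units; within the scatter) and a 1.2-fold higher number from compound 1 to compound 4 (0.06 log units; within the scatter) and a 1.4-fold higher number from compound 2 to compound 4 (0.13 log units; within the scatter) all stay within the scatter, so a three-membered non-aromatic ring on this nitrogen cannot be told apart from either substituted phenyl group or from methyl. The earlier compounds had shown this only for 3-chlorophenyl, 4-fluorophenyl and methyl, and compound 4 extends it to a non-aromatic ring, so the four compounds still cannot be ranked by the group at this place. Nothing measured here accounts for this flat response.

The compounds shown leave open whether the same holds when a group carrying a carboxylic acid or an amine sits on this nitrogen. They also leave open whether a longer alkyl chain or a morpholine ring there would move the number beyond the scatter.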